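The compounds below may be only part of what the source reports. "The series", "measured", "known", "first", "only" and "open" are said of these compounds alone.

Three members of the series have numbers in an ADME assay on cells for inhibition of cytochrome P450 11B1, mitochondrial (Homo sapiens), read by HPLC, with a stated time of 60 min; a higher number here means a weaker inhibitor, a lower number a stronger inhibitor. Compound 1 `Fc1ccc2nc(-c3cncnc3)n(C3CC3)c2c1` gives 5380 nM in this assay. Compound 2 `Fc1ccc2nc(-c3cnccn3)n(C3CC3)c2c1` reaches only the assay limit of > 10000 nM in this assay. Compound 3 `Cc1ncncc1-c1nc2cc(F)c(F)cc2n1C1CC1` gives 4160 nM in this assay. Among the compounds with values here, the one measured step, an at least 1.8-fold higher number from compound 1 to compound 2 (0.26 log units; that floor lies within the scatter), has only a floor, which comes from the limit of > 10000 nM in this assay, at which 1 of the 3 values shown sits, the limit reported for compound 2. Compound 3 and compound 1 sit within the usual scatter of each other, so no order between them is claimed.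

Compound 4 `CNc1ncncc1-c1nc2cc(F)c(F)cc2n1C1CC1` differs from compound 3 by methylamino in place of methyl on an aromatic carbon. Within the data shown here, no measured step touches this position or this kind of exchange; the single measured step swaps one six-membered ring for another and gives no direction for the move from compound 3 to compound 4. With nothing in the series to anchor a shift, the number for compound 4 is expected near that of compound 3, the step estimated as a 1.2-fold lower number from compound 3 to compound 4 (0.08 log units; within the scatter) in this assay. The estimate for compound 4 is 3500 nM, expected to fall between 1200 nM and 10000 nM, with a fair chance that this assay again returns only a limit.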

Compound 4, half-maximal inhibitory concentration: 390 nM
Compound 4: middle estimate off by 9.0-fold (0.95 log units), on the high side, and the stated range ends above it.
By their numbers in this assay, from the lowest: compound 4; then compounds 3 and 1 (each within the scatter of the next). At a limit, above all of these: compound 2.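

In this assay, the exchange of methyl for methylamino on the aromatic carbon next to the ring nitrogen and ortho to a large group gives an 11-fold lower number from compound 3 to compound 4 (1.03 log units; beyond the scatter). Within the data shown here, this is the first step that lies beyond the scatter with a measured number at both ends, and it shows that this position responds strongly to the group it carries, whereas the earlier step offered only a floor. The change adds one carbon-bearing nitrogen substituent with 1 hydrogen-bond donor and 1 hydrogen-bond acceptor, but nothing at hand explains the size of this step.

The compounds shown leave open whether the nitrogen link alone suffices, which an unsubstituted amine, dimethylamino or methoxy at this position would test. They also leave open whether a longer chain such as ethylamino keeps the lower number.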